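Ethyl in place of fluoro: an untested change

This account rests on a few compounds, and the source may have more. Where it says the series, first, only, none or still open, it means among the compounds named here.

Compound 1, `O=C(O)c1cnc2c(F)cccc2c1`: > 25 mg/kg
Compound 2, `O=C(O)c1cnc2cc(C(F)(F)F)ccc2c1`: > 25 mg/kg

Of the compounds shown here, two have so far been tested in a functional assay on the whole organism (strain Sprague-Dawley) for inhibition, with Rattus norvegicus as the target; a higher number here means that more compound is needed for the effect, a lower number that less compound is needed. Compound 1 `O=C(O)c1cnc2c(F)cccc2c1` gave > 25 mg/kg, which is a limit of the assay and not a number. Compound 2 `O=C(O)c1cnc2cc(C(F)(F)F)ccc2c1` likewise gave > 25 mg/kg, again a limit. Compound 1 therefore stands at the limit of > 25 mg/kg in this assay, at which 2 of the 2 values shown sit, and no measured value lies below it.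

Compound 3 `CCc1cccc2cc(C(=O)O)cnc12` has not yet been measured. It differs from compound 1 by ethyl in place of fluoro on an aromatic carbon. Among the compounds with values here, no pair of measured compounds differing in a single place is available, so the size of a step in this assay cannot be read from the data. With both known values sitting at a limit, no step beyond the scatter is expected in either direction. Compound 3 is expected to give about 25 mg/kg, within 10 mg/kg to 60 mg/kg. This estimate means a step of a number no higher from compound 1 to compound 3 (the limit leaves the size open), and it is expected that this assay may again report only a limit.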

Compound 3, minimum effective dose: > 50 mg/kg
Compound 3 gave a limit, no number; the forecaster's own chance of this, stated with the estimate: 70%; at least 2.0-fold (0.30 log units) between middle value and limit.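

In this assay compound 1 gave > 25 mg/kg which is a limit of the assay and not a number. Compound 3 gave > 50 mg/kg which is also a limit, and the step between these two compounds cannot be read. Going by these compounds, how much of either compound is needed for the effect stays open, as does whether ethyl or fluoro at this place calls for the lower dose.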